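Series notes: a phenylethenyl group added to compound 2

The source may report more compounds than this note shows. Statements on the series, on what has been measured and on what is new or still open speak of the compounds shown alone.

Measured so far:
compound 1, `CC1(C)C(/C=C/C=C2/N(CCCc3ccccc3)c3ccc(Br)cc3C2(C)C)=[N+](CCCc2ccccc2)c2ccc(Br)cc21`, 101%
compound 2, `CCCCN1/C(=C/C=C/c2sc3ccccc3[n+]2CCCC)Sc2ccccc21`, 79%
compound 3, `CCCCN1/C(=C/C=C/C2=[N+](CCCC)c3ccc(Cl)cc3C2(C)C)C(C)(C)c2cc(Cl)ccc21`, 34%

All three readings come from an assay for displacement of a labelled ligand from protein arginine N-methyltransferase 1 (Homo sapiens), read by scintillation proximity assay, with stated times of 5 min and 8 min, tested at 10 uM; a lower number here means a weaker effect, a higher number a stronger effect of the compound at the concentration tested. Compound 2 stands second of the three numbers: compound 1 gives a reading that lies higher, beyond the scatter, and compound 3 gives one that lies well lower, also beyond the scatter. Among the measured compounds shown here, no pair among the measured compounds differs in only one place, so no single step has been measured; the three compounds differ from one another at several positions at once, and nothing in them isolates the effect of one group.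

Compound 4, `CCCCN1/C(=C/C(/C=C/c2ccccc2)=C/c2sc3ccccc3[n+]2CCCC)Sc2ccccc21`, is not yet measured. Against compound 2 it changes in one place: 2-phenylethenyl in place of hydrogen on a double-bonded chain carbon bound to two double-bonded chain carbons. Compound 2 already lies fairly high in this assay, which leaves less room upward than downward. For the measured compounds named here, with no measured step of this kind to lean on, the expectation is a small change, close to the scatter, with no firm direction. The estimate for compound 4 in this assay is 82%, within 60% to 100%. The implied step, a number 3 percentage points higher from compound 2 to compound 4 (within the scatter), is expected to be small.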

Compound 4, a percentage reported as inhibition, at one concentration (the size of the read-out at that concentration, not a potency): 48%
For compound 4 the middle estimate is 34 percentage points above the measured one; measured number below the stated range.
By their numbers in this assay, from the lowest: compound 3; then compound 4; then compound 2; then compound 1.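

In this assay, among the compounds shown here, 2-phenylethenyl in place of hydrogen on a double-bonded chain carbon bound to two double-bonded chain carbons gives a number 31 percentage points lower from compound 2 to compound 4 (beyond the scatter), the first change that can be read at a single place. The earlier compounds shown here differ from one another at several positions at once, so they could not show that this chain carbon matters; this step shows that the reading is sensitive to what is placed there, and that the change lowers it rather than leaving it close to that of compound 2. No measurement shown gives a reason for this loss, and the step records its size and direction only.

With one substituent at this position, the step cannot separate the effect of the added phenyl ring from that of the added double bond, and it gives no trend across groups. As far as these compounds go, it remains open whether a methyl, a plain phenyl, or a chain ending in an amine or a carboxylic acid at the same carbon would give a smaller step, and whether the same change on the cores of compound 1 or compound 3 would give a step of similar size.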